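Methoxy and benzofuranyl variants on a nucleoside core

The compounds below may be only part of what the source reports. "The series", "measured", "known", "first", "only" and "open" are said of these compounds alone.

Of the compounds shown here, three have been measured in a functional assay on HepG2 cells (Homo sapiens) for antiproliferative activity, read by XTT assay, with a stated time of 72 h; on this read-out lower numbers stand for stronger inhibition and higher numbers for weaker inhibition. Compound 1 `COc1nc(N)nc2c1c(-c1cccs1)cn2[C@@H]1O[C@H](CO)[C@@H](O)[C@H]1O` sits at the assay limit: in this assay compound 1 gives > 20000 nM, a limit rather than a number. Compound 2 `Nc1nc(N)c2c(-c3cccs3)cn([C@@H]3O[C@H](CO)[C@@H](O)[C@H]3O)c2n1` likewise reaches only the limit, giving > 20000 nM in this assay. Compound 3 `Nc1nc(N)c2c(-c3cc4ccccc4o3)cn([C@@H]3O[C@H](CO)[C@@H](O)[C@H]3O)c2n1` also returns a limit, > 20000 nM, in this assay. All three values sit on the same line, (the limit of > 20000 nM in this assay, at which 3 of the 3 values shown sit), so no ordering among them can be read.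

Two single changes connect the measured compounds. From compound 2 to compound 1 the change is methoxy in place of amino on an aromatic carbon, and the step that the two limits leave unreadable from compound 2 to compound 1 cannot be sized, since both ends are limits. From compound 2 to compound 3 the cores differ by 1-benzofuran-2-yl in place of thiophen-2-yl on an aromatic carbon, and again the step that the two limits leave unreadable from compound 2 to compound 3 is unreadable.

Compound 4 `COc1nc(N)nc2c1c(-c1cc3ccccc3o1)cn2[C@@H]1O[C@H](CO)[C@@H](O)[C@H]1O` has not yet been measured. It differs from compound 3 by methoxy in place of amino on an aromatic carbon, the same change that separates compound 2 from compound 1, at a place described in identical words. The step is expected to be a step that the limit leaves unreadable from compound 3 to compound 4, resting on the unreadable step from the matched pair and on the limit shown for compound 3, > 20000 nM. Compound 4 is therefore estimated at 30000 nM in this assay, with a range from 12000 nM to 100000 nM, and most likely only a limit will be reported.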

Compound 4, half-maximal inhibitory concentration: > 20000 nM
Compound 4 was reported as a limit; the forecaster's own chance of this, stated with the estimate: 85%; the middle value is on the limit's open side.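

Compound 4 returns only a limit, as do compound 1 and compound 3, so neither step into compound 4 can be read in this assay: the limit of > 20000 nM in this assay, at which 4 of the 4 values shown sit.

The compounds shown leave open whether either change, methoxy in place of amino or 1-benzofuran-2-yl in place of thiophen-2-yl, alters antiproliferative activity at all, as none of them gives a number rather than a limit.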